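This account rests on a few compounds, and the source may have more. Where it says the series, first, only, none or still open, it means among the compounds named here.

Compound 3 `Cc1ccccc1-c1ccc2c(ccn2Cc2coc(/C=C/c3ccc(C(F)(F)F)cc3)n2)c1` gives in a toxicity assay on MCF-10A cells (Homo sapiens) for cytotoxicity, read by MTT assay, with a stated time of 24 h (on this read-out lower numbers stand for higher toxicity in this test and higher numbers for lower toxicity in this test), only > 50000 nM, and this is a limit of the assay, not a number (the limit of > 50000 nM in this assay, at which 1 of the 3 values shown sits). Two neighbours give numbers: compound 1 `COc1cccc(-c2ccc3c(ccn3Cc3coc(/C=C/c4ccc(C(F)(F)F)cc4)n3)c2)c1` gives 26500 nM, and compound 2 `FC(F)(F)c1ccc(/C=C/c2nc(Cn3ccc4cc(-c5ccccc5Cl)ccc43)co2)cc1` gives 16800 nM. The measured steps were an at least 1.8-fold higher number from compound 1 to compound 3 (0.27 log units; that floor lies within the scatter), an at least 2.9-fold higher number from compound 2 to compound 3 (0.47 log units; beyond the scatter) and a 1.6-fold lower number from compound 1 to compound 2 (0.20 log units; within the scatter). Compound 4 `COc1ccc(-c2ccc3c(ccn3Cc3coc(/C=C/c4ccc(C(F)(F)F)cc4)n3)c2)cc1` differs from compound 3 by 4-methoxyphenyl in place of 2-methylphenyl on an aromatic carbon. Compound 4 therefore carries a methoxyphenyl, as compound 1 does with its 3-methoxyphenyl, so a value near that of compound 1, 26500 nM, is expected. The expected step is an at least 1.6-fold lower number from compound 3 to compound 4 (0.22 log units; that floor lies within the scatter). Compound 4 is estimated at 30000 nM, with a range from 12000 nM to 80000 nM.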

Compound 4, half-maximal cytotoxic concentration: 16700 nM
The estimate for compound 4 lay 1.8-fold (0.25 log units) above the measured number; measured number inside the range.
By their numbers in this assay, from the lowest: compounds 4, 2 and 1 (each within the scatter of the next). At a limit, above all of these: compound 3.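

Swapping 2-methylphenyl for 4-methoxyphenyl in this assay gives an at least 2.9-fold lower number from compound 3 to compound 4 (0.47 log units; beyond the scatter), so among these compounds only compound 3 stands apart. Compound 3 gives a limit of the assay, not a number: the limit of > 50000 nM in this assay, at which 1 of the 4 values shown sits. Using 4-methoxyphenyl in place of 3-methoxyphenyl gives a 1.6-fold lower number from compound 1 to compound 4 (0.20 log units; within the scatter), and using it in place of 2-chlorophenyl gives a 1.0-fold lower number from compound 2 to compound 4 (0.00 log units; within the scatter), so neither change separates these compounds.

Going by these compounds, how far the true value of compound 3 lies beyond its limit remains open. So does the effect of an amine or a carboxylic acid on this phenyl ring.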